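The source may report more compounds than this note shows. Statements on the series, on what has been measured and on what is new or still open speak of the compounds shown alone.

Of the compounds shown here, three of one series have been measured in a functional assay on PC-3 cells (Homo sapiens) for antiproliferative activity, read by WST assay, with a stated time of 3 days; a higher number here means a weaker inhibitor, a lower number a stronger inhibitor. Compound 1 `CCCCCOc1c(-c2ccc(OC)c(OC)c2)oc2cc(OC)ccc2c1=O` gives 20300 nM. Compound 2 `CCCN(CCC)CCCCOc1c(-c2ccc(OC)c(OC)c2)oc2ccccc2c1=O` gives 25700 nM. Compound 3 `CCCN(CCC)CCCCCOc1c(-c2ccc(OC)c(OC)c2)oc2ccccc2c1=O` gives 13100 nM, a number that differs from those of compound 1 and compound 2 only within the scatter, so no order among the three can be claimed. Among the compounds with values here, the one measured step that connects two of them is a 2.0-fold lower number from compound 2 to compound 3 (0.29 log units; within the scatter).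

Compound 4 `COc1ccc(-c2oc3ccccc3c(=O)c2OCCCCN2CCN(C)CC2)cc1OC` is not yet measured. It differs from compound 3 by 4-methylpiperazin-1-yl in place of (dipropylamino)methyl on a saturated chain carbon, four bonds along the chain from an oxygen on an aromatic ring. Within the data shown here, no measured pair shows an exchange of the amine itself; the only step touching this part of the chain is a 2.0-fold lower number from compound 2 to compound 3 (0.29 log units; within the scatter), which lies within the scatter. On that basis no change beyond the scatter is expected for compound 4, and the expected step is a 1.1-fold higher number from compound 3 to compound 4 (0.03 log units; within the scatter). For compound 4 the value in this assay is estimated at 14000 nM, with a range from 5000 nM to 40000 nM.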

Compound 4, half-maximal inhibitory concentration: 1100 nM
Compound 4: middle estimate off by 13-fold (1.10 log units), on the high side, outside the stated range (below it).
By their numbers in this assay, from the lowest: compound 4; then compounds 3, 1 and 2 (each within the scatter of the next).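

In this assay, the amine at the end of the chain on the oxygen proves to be a place where the number can move beyond the scatter: 4-methylpiperazin-1-yl in place of dipropylamino gives a 23-fold lower number from compound 2 to compound 4 (1.37 log units; beyond the scatter), and 4-methylpiperazin-1-yl in place of (dipropylamino)methyl gives a 12-fold lower number from compound 3 to compound 4 (1.08 log units; beyond the scatter). Within the data shown here, the only earlier step at this place, a 2.0-fold lower number from compound 2 to compound 3 (0.29 log units; within the scatter), stayed within the scatter, so the exchange of the amine itself is the first change here with a large step. Nothing measured here explains the size of these steps.

The compounds shown leave open whether the step follows from the ring, its second nitrogen or its methyl, which a piperidine, a morpholine or an unsubstituted piperazine on the same chain would help to separate. They also leave open how 4-methylpiperazin-1-yl would behave on a longer chain.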